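The source may report more compounds than this note shows. Statements on the series, on what has been measured and on what is new or still open speak of the compounds shown alone.

Measured so far in a functional assay on the whole organism (strain ICR) for inhibition, with Mus musculus as the target, with stated times of 7 days and 2 h, at a dose of 10 umol/kg by the intraperitoneal route; on this read-out higher numbers stand for more inhibition at the one dose given (going by the name of the read-out) and lower numbers for less inhibition:
Compound 1 `O=C(O)c1cc(-c2ccc(C3CCNCC3)cc2)cc(-c2cn(-c3ccc(C(F)(F)F)cc3)nn2)c1`: 71.4%
Compound 2 `C#CCCCCN1CCC(c2ccc(-c3cc(C(=O)O)cc4cc(-c5ccc(C(F)(F)F)cc5)ccc34)cc2)CC1`: 42.7%
Compound 3 `NCCCNC(=O)c1ccc(-c2cc(C(=O)O)cc(-n3cc(-c4ccc(C(F)(F)F)cc4)nn3)c2)s1`: 74%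

Compound 3 gives the highest of the three numbers in this assay. Compound 1 sits within the scatter of it, so no order between those two can be claimed; compound 2 lies beyond the scatter, and of that pair compound 3 is the higher.

Compound 4 `O=C(O)c1cc(-c2ccc(C3CCNCC3)cc2)cc(-n2cc(-c3ccc(C(F)(F)F)cc3)nn2)c1` has not yet been measured in this assay. It differs from compound 3 at one aromatic carbon of the shared core: 4-(piperidin-4-yl)phenyl in place of 5-((3-aminopropyl)carbamoyl)thiophen-2-yl on an aromatic carbon. Within the data shown here, the group that enters is the one carried by compound 1, and compound 1 gives 71.4%, within the scatter of compound 3. Among the measured compounds shown here, no pair of measured compounds differs in one place, so no measured step sets the size of this change. The step of a number 6 percentage points lower from compound 3 to compound 4 (within the scatter) is expected to be small, none beyond the scatter. Compound 4 is expected to give 68%, with a range of 50% to 84%.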

Compound 4, a percentage reported as inhibition, in the whole organism at one dose (the size of the read-out at that dose, not a potency): 57.2%
The estimate for compound 4 lay 10.8 percentage points above the measured number; the range from low to high includes it.
By their numbers in this assay, from the lowest: compound 2; then compound 4; then compounds 1 and 3 (each within the scatter of the next).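

At this aromatic carbon of the shared core, the group carried matters in this assay: 4-(piperidin-4-yl)phenyl in place of 5-((3-aminopropyl)carbamoyl)thiophen-2-yl gives a number 16.8 percentage points lower from compound 3 to compound 4 (beyond the scatter). The two groups have the same heavy-atom count, so that count alone does not set the read-out at this position. No measurement on hand accounts for the step.

Which part of the departing group carries the difference remains open: the thiophene ring, the amide or the 3-aminopropyl chain. An alcohol in place of the amine of that chain, or a phenyl ring in place of the thiophene, would help separate these parts.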